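This account rests on a few compounds, and the source may have more. Where it says the series, first, only, none or still open, it means among the compounds named here.

Three compounds with a shared core have been examined so far in an ADME assay on HepG2 cells (Homo sapiens) for cytotoxicity, read by MTT assay, with a stated time of 72 h; a lower number here means that less compound is tolerated, a higher number that more compound is tolerated. Compound 1 (`Cc1ccc(-c2cc3nc(N)[nH]c(=O)c3s2)cc1`) yielded no number, its entry reading "nd(insoluble)" (no result reported) without a result. Compound 2 (`CC(C)(C)Nc1nc2cc(-c3ccc(Br)cc3)sc2c(=O)[nH]1`) gave 1400 nM and compound 3 (`CC(C)Nc1nc2cc(-c3ccc(Br)cc3)sc2c(=O)[nH]1`) gave 13400 nM as the higher of the two numbers. Compound 4 (`CC(C)Nc1nc2cc(-c3ccc(Cl)cc3)sc2c(=O)[nH]1`) differs from compound 3 by a single exchange (chloro in place of bromo on an aromatic carbon) with chloro in place of bromo on an aromatic carbon, para to a large group, so that 4-bromophenyl becomes 4-chlorophenyl. Among the compounds with values here, the only measured step (a 9.6-fold higher number from compound 2 to compound 3 (0.98 log units; beyond the scatter)) is beyond the scatter, but it is hydrogen in place of methyl on a saturated chain carbon, and both of its compounds carry bromo. Within the data shown here, no measured pair changes the halogen, so the data offer no direct guide to this exchange. A step beyond the scatter is therefore not expected in this assay and no direction is clearly favoured. The expectation rests on compound 3 and its 13400 nM reading. The expected step (a 1.1-fold higher number from compound 3 to compound 4 (0.05 log units; within the scatter)) is an estimate that stays within the scatter. Compound 4 is estimated at 15000 nM with an expected range (6000 nM to 40000 nM).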

Compound 4, half-maximal cytotoxic concentration: > 15600 nM
Compound 4 gave a limit, no number (the forecaster's own chance of this, stated with the estimate: 10%); middle value at least 1.0-fold (0.01 log units) from the limit.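

For compound 4 the reading in this assay is a limit of the assay and not a number: the limit of > 15600 nM in this assay, at which 1 of the 4 values shown sits. Even so, this is the first pair among the compounds shown that changes only the halogen on this aromatic carbon, para to a large group, and the step is an at least 1.1-fold higher number from compound 3 to compound 4 (0.06 log units; that floor lies within the scatter). The earlier measured pair changed only the chain on the ring nitrogen substituent, whereas this one shows that chloro in place of bromo brings no loss of tolerance in this assay, although the floor of the step stays within the scatter and so gives no size for any gain.

From the compounds shown here alone, how far the true value of compound 4 lies past its limit stays open, and so does whether the side chain of compound 2 would give the same low reading with chloro as it does with bromo on this ring. Also open, going by these compounds, is how fluoro, a methoxy group or a nitrile on the same aromatic carbon would compare with chloro and bromo in this assay.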